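The source may hold more compounds than are shown below. What is called first, only, known or untested is meant among the compounds shown, and "the series" means these compounds.

Compound 3 `CCC1C(=O)N(C)c2cnc(Nc3ccc(S(=O)(=O)NCC(C)C)cc3)nc2N1c1ccn(C)n1` gives the lowest number of the three measured compounds in a functional assay on MCF7 cells (Homo sapiens) for antiproliferative activity, read by CCK-8 assay, with a stated time of 72 h (on this read-out higher numbers stand for weaker inhibition of growth and lower numbers for stronger inhibition of growth), at 8350 nM. Compound 2 `CCC1C(=O)N(C)c2cnc(Nc3ccc(S(=O)(=O)NCCCO)cc3)nc2N1c1ccn(C)n1` gives 21600 nM in this assay, and compound 1 `CCC1C(=O)N(C)c2cnc(-n3ccc4cc(C(=O)NC)ccc43)nc2N1c1ccn(C)n1`, which differs over a larger part of the molecule, gives 35400 nM. The one single-point step among these three runs a 2.6-fold lower number from compound 2 to compound 3 (0.41 log units; beyond the scatter); the gap between compound 1 and compound 3 can be read only from their two numbers. Compound 4 `CCC1C(=O)N(C)c2cnc(Nc3ccc(S(=O)(=O)NCCO)cc3)nc2N1c1ccn(C)n1` differs from compound 3 by hydroxymethyl in place of isopropyl on a saturated chain carbon bound to a sulfonamide nitrogen. Going by the values given here, the one measured step that bears on this change is a 2.6-fold lower number from compound 2 to compound 3 (0.41 log units; beyond the scatter), where isopropyl replaced 2-hydroxyethyl at the same place and the number fell. The change to compound 4 removes isopropyl again and puts in hydroxymethyl, which brings back a hydroxyl on a saturated chain bound to the sulfonamide nitrogen, as in compound 2, though on a shorter chain. A step back upward of comparable size is therefore expected, a 2.2-fold higher number from compound 3 to compound 4 (0.33 log units; beyond the scatter), in the direction of compound 2. Compound 4 is accordingly estimated at 18000 nM in this assay, with a range from 7000 nM to 45000 nM.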

Compound 4, concentration for 50% growth inhibition: "not active" (no number reported)
Nothing numeric was reported for compound 4; the estimate stays without a comparison.
By their numbers in this assay, from the lowest: compound 3; then compounds 2 and 1 (each within the scatter of the next).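

In this assay compound 4 is reported only as "not active", without a number, so no new step can be read between compound 4 and compound 3. Nothing given here accounts for this result. The compounds shown leave open how large the change from isobutyl to 2-hydroxyethyl on the sulfonamide nitrogen is in growth inhibition.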